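From Methoxycarbonyl to Benzyloxycarbonyl on a Hydroxy Compound

This account rests on a few compounds, and the source may have more. Where it says the series, first, only, none or still open, it means among the compounds named here.

In a functional assay on A549 cells (Homo sapiens) for antiproliferative activity, read by MTT assay, with a stated time of 48 h (on this read-out higher numbers stand for weaker inhibition of growth and lower numbers for stronger inhibition of growth), compound 1 (`COC(=O)N1N=C(c2ccccc2)CC1c1cc(OC)c(OC)c(OC)c1`) gives 2880 nM and compound 3 (`COC(=O)N1N=C(c2cccc(O)c2)CC1c1cc(OC)c(OC)c(OC)c1`) gives 3170 nM. Placing hydroxy in place of hydrogen on an aromatic carbon amounts to a 1.1-fold higher number from compound 1 to compound 3 (0.04 log units; within the scatter). For the measured compounds named here, compound 3 therefore stands level with compound 1, and the only other reading in this assay is a limit. Going by the values given here, that limit belongs to compound 2 (`COc1ccc(C2=NN(C(=O)OCc3ccccc3)C(c3cc(OC)c(OC)c(OC)c3)C2)cc1`), the one measured compound carrying benzyloxycarbonyl, which gives > 10000 nM, (the limit of > 10000 nM in this assay, at which 1 of the 3 values shown sits).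

Compound 4 (`COc1cc(C2CC(c3cccc(O)c3)=NN2C(=O)OCc2ccccc2)cc(OC)c1OC`) follows from compound 3 by one change: phenyl in place of hydrogen on a saturated chain carbon bound to an oxygen next to a carbonyl group. This change turns methoxycarbonyl into benzyloxycarbonyl. Among the compounds with values here, no measured step isolates this change. The hydroxy step of compound 3, a 1.1-fold higher number from compound 1 to compound 3 (0.04 log units; within the scatter), suggests that the hydroxy group will matter little, while the limit of compound 2 at > 10000 nM points towards weaker inhibition of growth. A higher number is therefore expected, and the expected size is a 2.8-fold higher number from compound 3 to compound 4 (0.45 log units; beyond the scatter). For compound 4 the estimated value is 9000 nM, with an expected range from 3500 nM to 22000 nM.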

Compound 4, concentration for 50% growth inhibition: > 10000 nM
Compound 4 was reported as a limit; the forecaster's own chance of this, stated with the estimate: 50%; middle value at least 1.1-fold (0.04 log units) away from the limit.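

The change from methoxycarbonyl to benzyloxycarbonyl now has a readable step of its own: in this assay, phenyl in place of hydrogen on a saturated chain carbon bound to an oxygen next to a carbonyl group gives an at least 3.1-fold higher number from compound 3 to compound 4 (0.49 log units; beyond the scatter). Before this result, benzyloxycarbonyl appeared only on compound 2, and no single step isolated it, whereas here the 3-hydroxyphenyl group stays in place and this is the only difference. The reading for compound 4 is a limit, so the step fixes only a smallest size for the change, and compound 4 now stands with compound 2 at that limit: the limit of > 10000 nM in this assay, at which 2 of the 4 values shown sit.

The step between compound 2 and compound 4 cannot be read, which leaves open whether 3-hydroxyphenyl or 4-methoxyphenyl on a carbon with a double bond to nitrogen makes any difference once benzyloxycarbonyl is present. The compounds shown also leave open how ethoxycarbonyl or a longer chain such as butoxycarbonyl would read at this place, and so whether any carbon chain beyond methyl has this result or whether the phenyl ring is required.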